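Swapping Bromine for Fluorine on a Benzyl Group

The source may report more compounds than this note shows. Statements on the series, on what has been measured and on what is new or still open speak of the compounds shown alone.

Compound 3 `COc1ccc(C(=O)/C=C/c2ccc(OCc3cn(Cc4cccc(Br)c4)nn3)cc2)cc1` is the reference point here. In a functional assay on A549 cells (Homo sapiens) for inhibition, read by MTT assay, with a stated time of 48 h, tested at 10 uM (a lower number here means less inhibition of growth, a higher number more inhibition of growth at the concentration tested), compound 3 gives 47%. Within the data shown here, that is the highest of the three numbers measured so far, yet both of the other compounds sit within the usual scatter of it, so no ordering among them can be claimed. Compound 1 `O=C(/C=C/c1ccc(OCc2cn(Cc3cccc(Br)c3)nn2)cc1)c1ccc(Br)cc1` gives 44%, and compound 2 `COc1ccc(C(=O)/C=C/c2ccc(OCc3cn(Cc4ccccc4)nn3)cc2)cc1` gives 44%. The step of a number 3 percentage points higher from compound 1 to compound 3 (within the scatter) exchanges a bromine for a methoxy group on the ring attached to the carbonyl, and the step of a number 3 percentage points higher from compound 2 to compound 3 (within the scatter) places a bromine onto the benzyl ring. Neither of these changes moved the number beyond the scatter.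

Compound 4 `COc1ccc(C(=O)/C=C/c2ccc(OCc3cn(Cc4cccc(F)c4)nn3)cc2)cc1` differs from compound 3 in one place: fluoro in place of bromo on an aromatic carbon. The measured step that bears most directly on this is a number 3 percentage points higher from compound 2 to compound 3 (within the scatter), in which a halogen was introduced at exactly this spot without any effect beyond the scatter. Taking one halogen out and putting a smaller one in at the same place is therefore expected to leave the number essentially where it is. The step of a number 2 percentage points lower from compound 3 to compound 4 (within the scatter) is expected to remain within the scatter. For compound 4 the estimated value is 45%, with a likely range from 33% to 57%.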

Compound 4, percent growth inhibition at one concentration: 56%
Compound 4: the middle estimate sits 11 percentage points below what was measured; the measured number falls inside the stated range.
By their numbers in this assay, from the lowest: compounds 1, 2, 3 and 4 (each within the scatter of the next, the first and the last beyond it).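

Among these compounds, the fluoro compound gives the first step at this position to pass the scatter: in this assay, the change shows as a number 12 percentage points higher from compound 2 to compound 4 (beyond the scatter) whereas the bromo compound gave only a number 3 percentage points higher from compound 2 to compound 3 (within the scatter). A substituent on the benzyl ring can therefore alter growth inhibition at the concentration tested, so this position is not indifferent to change, at least for fluoro in place of hydrogen. Yet the direct exchange of halogens gives a number 9 percentage points higher from compound 3 to compound 4 (within the scatter), so fluoro and bromo cannot be told apart here, and no measurement available explains the result.

The compounds shown leave open whether a larger or different kind of group on the benzyl ring, such as an amine, a carboxylic acid or a longer chain, would carry the number further or lose it. They also leave open whether 3-fluorobenzyl would act the same way on the core of compound 1, which carries bromo rather than methoxy on the ring attached to the carbonyl.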